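Phenyl for furan-2-yl on the shared core

The source may hold more compounds than are shown below. What is called first, only, known or untested is meant among the compounds shown, and "the series" means these compounds.

Compound 1 `O=c1[nH]cnc2c1c(-c1cccs1)cn2[C@@H]1O[C@H](CO)[C@@H](O)[C@H]1O`: in a functional assay on HeLa S3 cells (Homo sapiens) for antiproliferative activity, read by XTT assay, with a stated time of 72 h (on this read-out higher numbers stand for weaker inhibition and lower numbers for stronger inhibition), compound 1 gives only a limit, > 20000 nM.
Compound 2 `O=c1[nH]cnc2c1c(-c1ccco1)cn2[C@@H]1O[C@H](CO)[C@@H](O)[C@H]1O`: in this assay compound 2 gives 5780 nM.
Compound 3 `O=c1[nH]cnc2c1c(-c1ccccc1)cn2[C@@H]1O[C@H](CO)[C@@H](O)[C@H]1O`: not yet measured.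

Compound 2 holds the only number shown; the other value is a limit. Among the compounds with values here, the single measured step, an at least 3.4-fold lower number from compound 1 to compound 2 (0.53 log units; beyond the scatter), starts at the limit of > 20000 nM in this assay, at which 1 of the 2 values shown sits, so its size is known only as a floor. Compound 3 differs from compound 2 by phenyl in place of furan-2-yl on an aromatic carbon. Within the data shown here, no measured step brings in phenyl, so the expectation rests on one step and is loose. Compound 3 is expected to give about 9000 nM in this assay, between 3000 nM and 25000 nM, meaning an estimated step of a 1.6-fold higher number from compound 2 to compound 3 (0.19 log units; within the scatter).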

Compound 3, half-maximal inhibitory concentration: > 20000 nM
Compound 3: no number, only a limit; the forecaster's own chance of this, stated with the estimate: 35%; at least 2.2-fold (0.34 log units) between middle value and limit.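

In this assay, phenyl in place of furan-2-yl on this aromatic carbon gives an at least 3.4-fold higher number from compound 2 to compound 3 (0.53 log units; beyond the scatter), so the six-membered carbon ring does not keep the activity of compound 2. Among the three groups shown here, only furan-2-yl gives a number; compound 3 gives only a limit, the same one as compound 1: the limit of > 20000 nM in this assay, at which 2 of the 3 values shown sit.

The step from compound 1 to compound 3 cannot be read, as both values are limits. Open, as far as these compounds go, is what an amine, a carboxylic acid or a pyridine ring on this carbon would give.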